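The source may report more compounds than this note shows. Statements on the series, on what has been measured and on what is new or still open speak of the compounds shown alone.

Of the compounds shown here, two have been measured so far in a functional assay on HCT-116 cells (Homo sapiens), read by fluorescence and BrdU incorporation, with a stated time of 48 h, tested at 10 uM; a lower number here means a stronger effect, a higher number a weaker effect of the compound at the concentration tested. Compound 1, with the structure `COc1cc(OC)c(C(=O)/C=C/c2ccccc2)c(OC)c1`, gives 19% in this assay, which is the lowest of the two numbers, and the one nearest to it is compound 2, with the structure `COc1cc(O)c(C(=O)/C=C/c2ccccc2OC)c(OC)c1`, which gives 42% in this assay, a value that stands well beyond the scatter above it. The two compounds differ in more than one place, so their values are reported here without reading a single change into them.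

Compound 3, with the structure `COc1cc(OC)c(C(=O)/C=C/c2ccc(Br)cc2)c(OC)c1`, has not been measured. It differs from compound 1 by bromo in place of hydrogen on an aromatic carbon. Among the compounds with values here, no single-change step between measured compounds is available to calibrate this kind of change, so the expectation rests on the value of compound 1 alone. Because compound 1 already gives 19% in this assay, compound 3 is expected to stay close to it, with a step from compound 1 to compound 3 of a number 3 percentage points higher from compound 1 to compound 3 (within the scatter) in this assay, which is within the scatter. Compound 3 is therefore estimated at 22% in this assay, in the range from 8% to 42%.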

Compound 3, a percentage reported as activity, at one concentration (the size of the read-out at that concentration, not a potency): 68%
Beside the measured number, compound 3's estimate is 46 percentage points below it; the measured number lies above the stated range.
By their numbers in this assay, from the lowest: compound 1; then compound 2; then compound 3.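

Putting bromo in place of hydrogen on an aromatic carbon of the unsubstituted phenyl ring gives, in this assay, a number 49 percentage points higher from compound 1 to compound 3 (beyond the scatter), which means a much weaker effect at the concentration tested. Within the data shown here, this is the first single change that can be read, and it shows that this position, para to a large group, is not indifferent to substitution: the phenyl to 4-bromophenyl change adds only one heavy atom, with no ring and no net charge, yet the read-out moves well beyond the scatter. Nothing available here bears on why this step is so large.

The compounds shown leave open whether this weakening belongs to bromo itself or would also appear with another group in the same place, such as chloro, an amine or a carboxylic acid. They also leave open whether bromo on another carbon of this ring would give a step of similar size, or whether the same change on a differently substituted core would behave as it does on the core of compound 1.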